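This account rests on a few compounds, and the source may have more. Where it says the series, first, only, none or still open, it means among the compounds named here.

Working notes on a two-compound series sharing one core. In a functional assay on MCF7 cells (Homo sapiens) for cytotoxicity, read by neutral red uptake, with a stated time of 3 days (a higher number here means a weaker inhibitor, a lower number a stronger inhibitor), compound 1 `[N-]=[N+]=Nc1c(F)c(N)c2c(=O)cc(-c3ccc(N)c(F)c3)oc2c1F` gives 460 nM and compound 2 `CN(C)CCC(=O)OCc1c(F)c(N)c2c(=O)cc(-c3ccc(N)c(F)c3)oc2c1F` gives 19 nM, the lower of the two numbers. Going by the values given here, the only measured step, a 24-fold lower number from compound 1 to compound 2 (1.38 log units; beyond the scatter), is large and beyond the scatter. It puts (((2-(dimethylamino)ethyl)carbonyl)oxy)methyl in place of azido on an aromatic carbon.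

Next is compound 3 `CN(C)CCCC(=O)OCc1c(F)c(N)c2c(=O)cc(-c3ccc(N)c(F)c3)oc2c1F`, which differs from compound 2 by (dimethylamino)methyl in place of dimethylamino on a saturated chain carbon, two bonds along the chain from a carbonyl carbon. The same difference reads 2-(dimethylamino)ethyl to 3-(dimethylamino)propyl. Among the compounds with values here, no measured step alters this chain, so the data hold no direct precedent, and the size of the azido replacement does not transfer to this much smaller change. The expectation therefore stays anchored on compound 2 at 19 nM, with no step beyond the scatter expected in this assay and no direction favoured.

The expected step is a 1.2-fold higher number from compound 2 to compound 3 (0.06 log units; within the scatter). For compound 3 the estimate is 22 nM, with an expected range of 7 nM to 70 nM.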

Compound 3, half-maximal inhibitory concentration: 29 nM
Compound 3: the middle estimate sits 1.3-fold (0.12 log units) below what was measured, within the range that was stated.
By their numbers in this assay, from the lowest: compounds 2 and 3 (each within the scatter of the next); then compound 1.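

In this assay, going by these compounds alone, the chain itself is now probed for the first time, and 3-(dimethylamino)propyl in place of 2-(dimethylamino)ethyl gives a 1.5-fold higher number from compound 2 to compound 3 (0.18 log units; within the scatter) as the whole measured effect of this change. At this level of resolution, the saturated chain carbon two bonds along from the carbonyl carbon accepts (dimethylamino)methyl in place of dimethylamino without a step beyond the scatter. The large separation from the azido compound is also no longer tied to a single chain, since a 16-fold lower number from compound 1 to compound 3 (1.20 log units; beyond the scatter) stands alongside the earlier large step, and no measurement available here bears on the cause of either result.

Two chain lengths define no trend, so a 4-(dimethylamino)butyl chain, or a morpholine or a primary amine in place of dimethylamino, remains an open test of how far this position stays flat. The azido replacement also changes the whole substituent at once, which leaves open how much of the large step belongs to the ester, the amine or the chain, and an amide in place of the ester or the chain without its terminal amine would begin to separate these parts.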